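Swapping the carbamate for a sulfonamide in compound 3

The source may hold more compounds than are shown below. What is called first, only, known or untested is meant among the compounds shown, and "the series" means these compounds.

Of the compounds shown here, three sharing one amide-linked core have been tested in an assay on isolated protein for inhibition of microsomal triglyceride transfer protein large subunit (Homo sapiens); a lower number here means a stronger inhibitor, a higher number a weaker inhibitor. Compound 1 `Cc1cccc(C(=O)Nc2ccc3c(c2)CC(NS(C)(=O)=O)C3)c1-c1ccc(Cl)cc1` gives 100 nM. Compound 2 `Cc1cccc(C(=O)Nc2ccc3c(c2)CC(NS(=O)(=O)c2cccs2)C3)c1-c1ccc(Cl)cc1`, which carries a thiophen-2-yl in place of methyl on the sulfonyl sulfur, gives 120 nM; the step is a 1.2-fold higher number from compound 1 to compound 2 (0.08 log units; within the scatter). Compound 3 `COC(=O)NCC1Cc2ccc(NC(=O)c3cccc(C)c3-c3ccc(Cl)cc3)cc2C1`, with a ((methoxycarbonyl)amino)methyl in place of the methanesulfonamido group on the saturated ring carbon, gives 100 nM; that step is no change at the digits printed from compound 1 to compound 3 (within the scatter), and compared with compound 2 the step is a 1.2-fold lower number from compound 2 to compound 3 (0.08 log units; within the scatter). Compound 3 thus stands level with compound 1, and all three numbers lie within the usual scatter of one another.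

Compound 4 `Cc1cccc(C(=O)Nc2ccc3c(c2)CC(CNS(C)(=O)=O)C3)c1-c1ccc(Cl)cc1` has not yet been measured. It differs from compound 3 in one place: methylsulfonyl in place of methoxycarbonyl on an amine nitrogen. The measured steps that bear on this are the change of the group on the sulfonyl sulfur, a 1.2-fold higher number from compound 1 to compound 2 (0.08 log units; within the scatter), and the exchange of the whole substituent on the ring carbon, no change at the digits printed from compound 1 to compound 3 (within the scatter), both within the scatter. Nothing among these compounds points to a shift beyond the scatter, so the step from compound 3 to compound 4 in this assay is expected to be no change at the digits printed from compound 3 to compound 4 (within the scatter). Compound 4 is therefore estimated at 100 nM, with a range from 50 nM to 200 nM.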

Compound 4, half-maximal inhibitory concentration: 500 nM
Estimate against measurement, compound 4: 5.0-fold (0.70 log units) below; the measured number lies above the stated range.
By their numbers in this assay, from the lowest: compounds 1, 3 and 2 (each within the scatter of the next); then compound 4.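

In this assay, the group on the amine nitrogen turns out to matter at this position: methylsulfonyl in place of methoxycarbonyl gives a step beyond the scatter (a 5.0-fold higher number from compound 3 to compound 4 (0.70 log units; beyond the scatter)), although the two groups match in heavy-atom count and in hydrogen-bond donors and acceptors. How the sulfonamide is attached to the saturated ring carbon matters as well, as (methanesulfonamido)methyl in place of methanesulfonamido gives (a 5.0-fold higher number from compound 1 to compound 4 (0.70 log units; beyond the scatter)) and in place of ((thiophen-2-yl)sulfonyl)amino gives (a 4.2-fold higher number from compound 2 to compound 4 (0.62 log units; beyond the scatter)), whereas every earlier step stayed within the scatter. No measurement is available that would account for these steps.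

Going by these compounds, it remains open whether thiophen-2-yl on the sulfonyl sulfur would give the same result when attached through the (methanesulfonamido)methyl arrangement, and whether (methoxycarbonyl)amino placed directly on the ring carbon would match compound 3. A free amine or a carboxylic acid at this position, or a longer chain between the ring carbon and the nitrogen, would show how far this sensitivity extends.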